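The source may hold more compounds than are shown below. What is called first, only, known or untested is meant among the compounds shown, and "the series" means these compounds.

Three compounds share one core and differ only in the group attached to the aromatic ring. Compound 1 `O=C1CCCN(c2cccc(Cl)c2)N1` carries a chloro there, and in an assay on isolated protein for inhibition of Polyunsaturated fatty acid 5-lipoxygenase (Homo sapiens) (a lower number here means a stronger inhibitor, a higher number a weaker inhibitor), compound 1 gives 2500 nM. Compound 2 `O=C1CCCN(c2cccc(Br)c2)N1` carries a bromo instead; in this assay compound 2 gives 1800 nM, so the step of a 1.4-fold lower number from compound 1 to compound 2 (0.14 log units; within the scatter) changes little. Compound 3 `CC(=O)c1cccc(N2CCCC(=O)N2)c1` carries an acetyl; in this assay compound 3 gives 19000 nM, the highest of the three numbers and so the weakest inhibitor among them. The steps of a 7.6-fold higher number from compound 1 to compound 3 (0.88 log units; beyond the scatter) and an 11-fold higher number from compound 2 to compound 3 (1.02 log units; beyond the scatter) both run the same way, from a halogen to the acetyl.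

Compound 4 `N#Cc1cccc(N2CCCC(=O)N2)c1` is the next change: cyano in place of acetyl on an aromatic carbon. For the measured compounds named here, no measured step exchanges one non-halogen group for another, so the two halogen-to-acetyl steps only show how far a single change on this ring has moved the number before. The step of a 1.3-fold lower number from compound 3 to compound 4 (0.10 log units; within the scatter) is therefore expected to be small, with no firm direction. Compound 4 is expected to give 15000 nM in this assay, with a range from 5000 nM to 45000 nM.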

Compound 4, half-maximal inhibitory concentration: 9300 nM
The estimate for compound 4 lay 1.6-fold (0.21 log units) above the measured number; measured number inside the range.
By their numbers in this assay, from the lowest: compounds 2 and 1 (each within the scatter of the next); then compound 4; then compound 3.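

In this assay, for the compounds shown here, the step of a 2.0-fold lower number from compound 3 to compound 4 (0.31 log units; beyond the scatter) is the first exchange here of one non-halogen group for another, and it lies just beyond the scatter, so acetyl and cyano are not interchangeable at this position. The cyano group still does not match either halogen: the step of a 5.2-fold higher number from compound 2 to compound 4 (0.71 log units; beyond the scatter) and the step of a 3.7-fold higher number from compound 1 to compound 4 (0.57 log units; beyond the scatter) both run upward, which places the numbers in the order halogens, then cyano, then acetyl. Nothing measured on these compounds bears on why the numbers fall in this order. Going by these compounds, how an amine, a carboxylic acid or a longer chain would compare at this position stays open. On these data alone, whether the same order holds with these groups elsewhere on the aromatic ring also stays open.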